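Carboxyphenyl replacement at the linker oxygen: compound 4

The source may hold more compounds than are shown below. What is called first, only, known or untested is meant among the compounds shown, and "the series" means these compounds.

Measured so far:
- compound 2, `Cc1ccc(C(=O)O)cc1OCCCCOc1ccc(C(=O)CC2CCCC2)c(O)c1C`: 1290 nM
- compound 3, `Cc1cc(C(=O)O)ccc1OCCCCOc1ccc(C(=O)CC2CCCC2)c(O)c1C`: 608 nM
- compound 1, `Cc1c(OCCCCOc2ccc(F)c(C(=O)O)c2)ccc(C(=O)CC2CCCC2)c1C`: "not determined" (no result reported)

In an assay on HEK293 cells for positive allosteric modulation of metabotropic glutamate receptor 2 (Rattus norvegicus), read by thallium flux, with a stated time of 2.5 min (a higher number here means that more compound is needed for the effect, a lower number that less compound is needed), compound 3 holds the lowest of the two numbers reported; its nearest neighbour is compound 2, and the step of a 2.1-fold lower number from compound 2 to compound 3 (0.33 log units; beyond the scatter) is modest but beyond the scatter. Compound 1, which carries a methyl where compounds 2 and 3 carry a hydroxyl on the core, has no number.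

Compound 4, `Cc1c(OCCCCOc2ccc(F)c(C(=O)O)c2)ccc(C(=O)CC2CCCC2)c1O`, differs from compound 3 in one place: 3-carboxy-4-fluorophenyl in place of 4-carboxy-2-methylphenyl on an oxygen on a saturated carbon. For the measured compounds named here, the only measured step, a 2.1-fold lower number from compound 2 to compound 3 (0.33 log units; beyond the scatter), concerns a shift of the carboxyl on an otherwise unchanged methylphenyl and therefore bears only loosely on the present change, where the methyl is also exchanged for a fluorine and the carboxyl moves once more. Nothing measured gives the direction of such an exchange, so no step beyond the scatter is expected in this assay; the prior for compound 4 is roughly the number of compound 3 with a wide band around it.

For compound 4 the estimate in this assay is 800 nM, with a range from 300 nM to 2200 nM, which corresponds to an expected step of a 1.3-fold higher number from compound 3 to compound 4 (0.12 log units; within the scatter).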

Compound 4, half-maximal effective concentration: 699 nM
Compound 4: middle estimate off by 1.1-fold (0.06 log units), on the high side; the measured number falls inside the stated range.
By their numbers in this assay, from the lowest: compounds 3, 4 and 2 (each within the scatter of the next, the first and the last beyond it).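

In this assay, 3-carboxy-4-fluorophenyl in place of 4-carboxy-2-methylphenyl on the oxygen gives a 1.1-fold higher number from compound 3 to compound 4 (0.06 log units; within the scatter), so this position accepts a carboxyphenyl with a fluorine and no methyl, with no change that can be read from the numbers. Set against the other methyl-bearing group, 5-carboxy-2-methylphenyl, the exchange gives a 1.8-fold lower number from compound 2 to compound 4 (0.27 log units; within the scatter), so compound 4 lies within the scatter of both methyl-bearing compounds, although those two are separated by a 2.1-fold lower number from compound 2 to compound 3 (0.33 log units; beyond the scatter), which is beyond it. No measurement at hand explains why these three groups give such close numbers.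

As far as these compounds go, the exchange alters the substituent and the carboxyl placement at once, so the contributions of the fluorine, the lost methyl and the moved carboxyl remain unseparated, and it stays open whether a tetrazole or a primary amide could stand in for the carboxylic acid on this ring. Steps to compound 1 cannot be read, which leaves open what a methyl in place of the hydroxyl on the shared core does when the 3-carboxy-4-fluorophenyl group is present.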